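This account rests on a few compounds, and the source may have more. Where it says the series, first, only, none or still open, it means among the compounds named here.

Three compounds with a shared core have been examined in a functional assay on HeLa cells (Homo sapiens) for cytotoxicity, read by MTT assay, with a stated time of 72 h; a lower number here means a stronger inhibitor, a higher number a weaker inhibitor. Compound 1 `O=C1c2cccc([N+](=O)[O-])c2NC[C@@]12[C@H](c1ccc(Br)cc1)[C@@H](c1ccccc1)N[C@]21C(=O)Nc2ccc(Br)cc21` gives 25000 nM, compound 2 `O=C1c2cccc([N+](=O)[O-])c2NC[C@@]12[C@H](c1ccc(F)cc1)[C@@H](c1ccccc1)N[C@]21C(=O)Nc2ccc(Br)cc21` gives 26000 nM, and compound 3 `COc1ccc([C@@H]2[C@@H](c3ccccc3)N[C@]3(C(=O)Nc4ccc(Br)cc43)[C@]23CNc2c(cccc2[N+](=O)[O-])C3=O)cc1` gives 19000 nM. Compound 2 carries the top number of the three, yet the steps of a 1.0-fold higher number from compound 1 to compound 2 (0.02 log units; within the scatter) and a 1.4-fold lower number from compound 2 to compound 3 (0.14 log units; within the scatter) both fall within the scatter, as does a 1.3-fold lower number from compound 1 to compound 3 (0.12 log units; within the scatter). Compound 4 `O=C1c2cccc([N+](=O)[O-])c2NC[C@@]12[C@H](c1ccc(F)cc1)[C@@H](c1ccccc1)N[C@]21C(=O)Nc2ccc(F)cc21` differs from compound 2 by fluoro in place of bromo on an aromatic carbon. The same exchange, at another aromatic carbon, gave a 1.0-fold higher number from compound 1 to compound 2 (0.02 log units; within the scatter), and the other swaps at that site also stayed within the scatter. No step beyond the scatter is therefore expected in this assay for compound 4; its number is estimated at 26000 nM, between 13000 nM and 52000 nM, a step of no change at the digits printed from compound 2 to compound 4 (within the scatter).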

Compound 4, half-maximal inhibitory concentration: 20000 nM
For compound 4 the middle estimate is 1.3-fold (0.11 log units) above the measured one, and the stated range covers the measured number.
By their numbers in this assay, from the lowest: compounds 3, 4, 1 and 2 (each within the scatter of the next).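

In this assay, replacing bromo with fluoro on the aromatic carbon that is meta to a fused ring and para to a fused ring gives a 1.3-fold lower number from compound 2 to compound 4 (0.11 log units; within the scatter) and is the first change shown at this site. The exchange therefore stays within the scatter at this second site as well as at the site varied among compound 1, compound 2 and compound 3. Nothing available bears on this result.

The compounds shown carry only bromo and fluoro at this position, so what an amine or a carboxylic acid there would do in this assay remains open.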